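A Methyl Addition Tried Twice Across a Small Series

The compounds below may be only part of what the source reports. "The series", "measured", "known", "first", "only" and "open" are said of these compounds alone.

Measured in a functional assay on HeLa cells (Homo sapiens) for cytotoxicity, read by sulforhodamine B assay; on this read-out higher numbers stand for weaker inhibition and lower numbers for stronger inhibition:
Compound 1, `Cn1c2c(c3ccccc3c1=O)CCOc1ccccc1-2`: 19700 nM
Compound 2, `Cc1ccc2c3c(n(C)c(=O)c2c1)-c1ccccc1OCC3`: 8760 nM
Compound 3, `COc1ccc(Cn2c3c(c4ccccc4c2=O)CCOc2ccccc2-3)cc1`: 4780 nM

Compound 1 is the parent of this small set. Compound 2 differs from it by methyl in place of hydrogen on an aromatic carbon, and this change gave a 2.2-fold lower number from compound 1 to compound 2 (0.35 log units; beyond the scatter). Compound 3 differs from compound 1 in another way, (4-methoxyphenyl in place of hydrogen on a saturated chain carbon bound to an aromatic nitrogen), and this change gave a 4.1-fold lower number from compound 1 to compound 3 (0.62 log units; beyond the scatter). Compound 2 and compound 3 lie within the scatter of each other, so nothing separates them with confidence.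

The unmeasured compound 4, `COc1ccc(Cn2c3c(c4cc(C)ccc4c2=O)CCOc2ccccc2-3)cc1`, differs from compound 3 by methyl in place of hydrogen on an aromatic carbon. This is the same change as that from compound 1 to compound 2, at the same place on the same ring, but now made on a core that already carries 4-methoxybenzyl in place of methyl. Whether the two changes simply add up cannot be checked from the three measured compounds. Going by the values given here, the expectation for compound 4 therefore rests on the single earlier instance of this change, the step from compound 1 to compound 2 of a 2.2-fold lower number from compound 1 to compound 2 (0.35 log units; beyond the scatter), and a step of roughly that size is expected again, which would mean a 2.1-fold lower number from compound 3 to compound 4 (0.32 log units; beyond the scatter) in this assay. Compound 4 is thus estimated at 2300 nM, with a range expected from 1000 nM to 5500 nM.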

Compound 4, half-maximal inhibitory concentration: 10300 nM
Compound 4: the middle estimate sits 4.5-fold (0.65 log units) below what was measured; measured number above the stated range.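

On the core that carries 4-methoxybenzyl, methyl in place of hydrogen on an aromatic carbon gave a 2.2-fold higher number from compound 3 to compound 4 (0.33 log units; beyond the scatter) in this assay, so the number moved the opposite way from the earlier step on the core of compound 1, and inhibition became weaker rather than stronger. Set side by side, the two steps differ in direction as well as in value: the same change on two cores in this assay, a 2.2-fold lower number (0.35 log units; beyond the scatter) from compound 1 to compound 2 and a 2.2-fold higher number (0.33 log units; beyond the scatter) from compound 3 to compound 4, 4.8-fold (0.69 log units) apart, beyond the scatter of two such steps. Going by these compounds alone, this shows that the effect of the methyl cannot simply be carried from one core to the other, although it does not show why the sign flips, and with only one pair on each core it offers no general rule for other cores.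

The compounds shown leave open whether the reversal belongs to methyl alone or would also appear with another group on that same aromatic carbon, such as chlorine or ethyl. They also leave open how the methyl step would behave with a different group on the ring nitrogen, such as plain benzyl or a longer chain like butyl, which could show whether the 4-methoxyphenyl part matters for the flip.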